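A Fluorine Added Where Nothing Stood Before

The compounds below may be only part of what the source reports. "The series", "measured", "known", "first", "only" and "open" are said of these compounds alone.

Compound 3 `CC(=O)c1cc(/C=C/c2ccc(F)cc2)cc2cc(-c3ccccc3)[nH]c12` gives the lowest number among the three compounds measured in a functional assay on HeLa cells (Homo sapiens) for cytotoxicity, read by MTT assay, with a stated time of 2 days, tested at 10 uM; a lower number here means a stronger effect, a higher number a weaker effect of the compound at the concentration tested: compound 3 gives 32.8%. Its nearest neighbour is compound 2 `COc1ccc(-c2cc(C(C)=O)c3[nH]c(-c4ccc(F)cc4)cc3c2)cc1`, which gives 46.5% in this assay, a number beyond the scatter above it, and the furthest is compound 1 `CC(=O)c1cc(-c2ccc(F)cc2)cc2cc(-c3ccc(F)cc3)[nH]c12`, which gives 47.4% in this assay.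

Compound 4 `CC(=O)c1cc(/C=C/c2ccc(F)cc2)cc2cc(-c3ccc(F)cc3)[nH]c12` differs from compound 3 in one place: fluoro in place of hydrogen on an aromatic carbon. Cut one bond further out, the same change reads phenyl to 4-fluorophenyl.

Going by the values given here, the only measured step that joins two compounds differing in a single place is a number 0.9 percentage points lower from compound 1 to compound 2 (within the scatter). Among the compounds with values here, that step swapped one group for another on a different six-membered aromatic ring and stayed within the scatter, so it does not touch the place changed here, and no measured step bears directly on adding fluoro in place of hydrogen. With nothing pointing to a shift in either direction, the step expected for compound 4 is a number 1.2 percentage points higher from compound 3 to compound 4 (within the scatter), a change no larger than the scatter.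

Compound 4 is therefore estimated to give 34% in this assay, with a likely range from 22% to 47%.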

Compound 4, a percentage reported as activity, at one concentration (the size of the read-out at that concentration, not a potency): 41.9%
The estimate for compound 4 lay 7.9 percentage points below the measured number; the range from low to high includes it.
By their numbers in this assay, from the lowest: compounds 3, 4, 2 and 1 (each within the scatter of the next, the first and the last beyond it).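

In this assay, going by these compounds alone, this is the first direct test of the phenyl ring at this position, and fluoro in place of hydrogen, para to a large group, gives a number 9.1 percentage points higher from compound 3 to compound 4 (within the scatter) so this change cannot be told apart from repeat-to-repeat variation. With that fluoro in place, the group on the other side of the core can also be exchanged without a clear effect: 2-(4-fluorophenyl)ethenyl in place of 4-methoxyphenyl gives a number 4.6 percentage points lower from compound 2 to compound 4 (within the scatter) and 2-(4-fluorophenyl)ethenyl in place of 4-fluorophenyl gives a number 5.5 percentage points lower from compound 1 to compound 4 (within the scatter) so neither exchange separates compound 4 from the compound it is compared with. Nothing measured here offers an explanation for these numbers.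

The compounds shown leave open whether a larger or charged group on that phenyl ring, such as an amine or a carboxylic acid, would shift the number beyond the scatter. They also leave open how these compounds compare in potency, as each number is the size of the effect at one concentration only.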